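Sulfonate ureas on melanoma cells: working notes

The source may hold more compounds than are shown below. What is called first, only, known or untested is meant among the compounds shown, and "the series" means these compounds.

Measured so far:
compound 1 `CCNC(=O)Nc1cccc(S(=O)(=O)Oc2ccccc2CC)c1` gives 30000 nM in a functional assay on M21 cells (Homo sapiens) for cytotoxicity, read by sulforhodamine B assay, with a stated time of 48 h; a higher number here means a weaker inhibitor, a lower number a stronger inhibitor
compound 2 `CCNC(=O)Nc1cccc(S(=O)(=O)Oc2ccc(O)cc2)c1` gives 42000 nM
compound 3 `CCNC(=O)Nc1ccc(S(=O)(=O)Oc2ccccc2CC)cc1` gives 2500 nM

Compound 3 has the same atoms as compound 1 joined differently; the difference between the two cores is not broken down here. Its number stands lowest of the three, and both gaps to it lie beyond the scatter. The change 4-hydroxyphenyl in place of 2-ethylphenyl on an oxygen gave a 1.4-fold higher number from compound 1 to compound 2 (0.15 log units; within the scatter) on the core of compound 1.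

Compound 4 `CCNC(=O)Nc1ccc(S(=O)(=O)Oc2ccc(O)cc2)cc1` is not yet measured. It carries the same change on the core of compound 3, (4-hydroxyphenyl in place of 2-ethylphenyl on an oxygen). Within the data shown here, the step in this assay is estimated to be about the size of the earlier one, a 1.4-fold higher number from compound 3 to compound 4 (0.15 log units; within the scatter), because a 1.4-fold higher number from compound 1 to compound 2 (0.15 log units; within the scatter) is the only precedent for this change. Compound 4 is therefore expected to give 3500 nM, estimated to fall between 1500 nM and 9000 nM.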

Compound 4, half-maximal inhibitory concentration: 4300 nM
For compound 4 the middle estimate is 1.2-fold (0.09 log units) below the measured one, within the range that was stated.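

In this assay the change to 4-hydroxyphenyl in place of 2-ethylphenyl on an oxygen gave a 1.7-fold higher number from compound 3 to compound 4 (0.24 log units; within the scatter) and so behaved alike on both cores: the same change on two cores in this assay, a 1.4-fold higher number (0.15 log units; within the scatter) from compound 1 to compound 2 and a 1.7-fold higher number (0.24 log units; within the scatter) from compound 3 to compound 4, 1.2-fold (0.09 log units) apart, within the scatter of two such steps.

Across these two pairs the change carries from the core of compound 1 to the core of compound 3, and each core's number stays within the scatter. This rests on a single change and two pairs, and it does not show that any other group on that oxygen would carry over in the same way.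

The compounds shown hold only two groups on the oxygen and only ethyl on the urea. As far as these compounds go, a carboxylic acid or an amine on the phenyl ring, or a longer chain in place of the ethyl, remains open.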